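The source may hold more compounds than are shown below. What is called first, only, known or untested is meant among the compounds shown, and "the series" means these compounds.

Working notes on the series. Three compounds share one core: compound 1 `Cc1cc(/C=C/C#N)ccc1Nc1ccnc(Nc2ccc(C#N)cc2)n1`, compound 2 `COc1cc(/C=C/C#N)cc(C)c1Nc1ccnc(Nc2ccc(C#N)cc2)n1` and compound 3 `Cc1cc(/C=C/C#N)cc(Cl)c1Nc1ccnc(Nc2ccc(C#N)cc2)n1`. In an ADME assay on MT4 cells (Homo sapiens) for cytotoxicity, with a stated time of 3 days (a lower number here means that less compound is tolerated, a higher number that more compound is tolerated), compound 1 gives > 25000 nM, which is a limit of the assay rather than a number, namely (the limit of > 25000 nM in this assay, at which 1 of the 3 values shown sits). Compound 2 gives 633 nM. Compound 3 gives 2610 nM, the highest of the two numbers available; its nearest neighbour is compound 2, with a 4.1-fold higher number from compound 2 to compound 3 (0.62 log units; beyond the scatter). The two substitutions made on compound 1 gave an at least 39-fold lower number from compound 1 to compound 2 (1.59 log units; beyond the scatter) and an at least 9.5-fold lower number from compound 1 to compound 3 (0.98 log units; beyond the scatter).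

Compound 4 `COc1cc(/C=C/C#N)cc(Cl)c1Nc1ccnc(Nc2ccc(C#N)cc2)n1` differs from compound 3 by methoxy in place of methyl on an aromatic carbon. Among the compounds with values here, no measured pair shows methoxy replacing methyl. The nearest guides are the step into compound 2, where methoxy entered, and the step into compound 3, where chloro entered; both lowered the number. Compound 4 carries both groups, so a lower number than compound 3 is expected, a 3.3-fold lower number from compound 3 to compound 4 (0.51 log units; beyond the scatter). Compound 4 is therefore estimated at 800 nM, within a range of 200 nM to 3000 nM.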

Compound 4, half-maximal cytotoxic concentration: 398 nM
Estimate against measurement, compound 4: 2.0-fold (0.30 log units) above, and the stated range covers the measured number.
By their numbers in this assay, from the lowest: compounds 4 and 2 (each within the scatter of the next); then compound 3. At a limit, above all of these: compound 1.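

Within the data shown here, with chloro held constant in this assay, methoxy in place of methyl gives a 6.6-fold lower number from compound 3 to compound 4 (0.82 log units; beyond the scatter), the first direct reading of this exchange at this position, ortho to a large group. With methoxy held constant, chloro in place of methyl gives a 1.6-fold lower number from compound 2 to compound 4 (0.20 log units; within the scatter), so among the three numbers the two methoxy compounds stay within the scatter of each other and compound 3, which lacks methoxy, stands apart. No measured property shown here bears on the reason for this change.

On these data alone, it remains open whether the lower number is specific to methoxy or would also appear with hydroxy, an amine or a longer ether such as ethoxy at this position. As far as these compounds go, it is also open whether the same exchange would give a step of similar size with a group other than chloro on the ring.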